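This account rests on a few compounds, and the source may have more. Where it says the series, first, only, none or still open, it means among the compounds named here.

Going by the values given here, compound 2 `Cc1cc(-c2c(C)nn(-c3nc(-c4ccc(Cl)c(Cl)c4)c(SC(C)C)s3)c2C(=O)O)cc(C)n1` holds the lower of the two numbers known so far: in a functional assay on BJAB cells (Homo sapiens) for antiproliferative activity, with a stated time of 4 days (on this read-out lower numbers stand for an effect already at smaller amounts and higher numbers for an effect only at larger amounts of compound), compound 2 gives 580 nM, while compound 1 `Cc1nn(-c2nc(-c3ccc(Cl)c(Cl)c3)c(SC(C)C)s2)c(C(=O)O)c1-c1cccc(Cl)c1C` gives 5100 nM. Among the compounds with values here, that gap, an 8.8-fold lower number from compound 1 to compound 2 (0.94 log units; beyond the scatter), is the only measured step available, and it swapped in the whole dimethylpyridinyl group at once. Compound 3 `Cc1nn(-c2nc(-c3ccc(Cl)c(Cl)c3)c(SC(C)C)s2)c(C(=O)O)c1-c1ccncc1` differs from compound 2 by pyridin-4-yl in place of 2,6-dimethylpyridin-4-yl on an aromatic carbon. Within the data shown here, no measured step strips the two methyl groups alone, so the earlier step bears on this change only loosely and a smaller movement is anticipated. Compound 3 is therefore expected to give 1100 nM, in a range from 400 nM to 3000 nM, meaning an expected step of a 1.9-fold higher number from compound 2 to compound 3 (0.28 log units; within the scatter).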

Compound 3, half-maximal effective concentration: 5900 nM
For compound 3 the middle estimate is 5.4-fold (0.73 log units) below the measured one; the measured number lies above the stated range.
By their numbers in this assay, from the lowest: compound 2; then compounds 1 and 3 (each within the scatter of the next).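

Swapping 2,6-dimethylpyridin-4-yl for pyridin-4-yl gives a 10-fold higher number from compound 2 to compound 3 (1.01 log units; beyond the scatter), so at this position the two methyl groups on the ring account for the whole gain seen earlier, and the ring nitrogen alone brings none. Without them, the pyridin-4-yl and 3-chloro-2-methylphenyl groups cannot be told apart: a 1.2-fold higher number from compound 1 to compound 3 (0.06 log units; within the scatter). Nothing available explains why the two methyl groups matter so much. On these data alone, it remains open whether one methyl group on the pyridin-4-yl would be enough, and whether an ethyl group or an amine in those places would serve as well.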